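Biaryl terminus: pyridyl to cyanophenyl in the cyclopropane amides

The compounds below may be only part of what the source reports. "The series", "measured", "known", "first", "only" and "open" are said of these compounds alone.

In a functional assay for agonist activity at G protein-coupled receptor 88 (Homo sapiens), read by HTRF and cAMP accumulation (on this read-out higher numbers stand for an effect only at larger amounts of compound and lower numbers for an effect already at smaller amounts), compound 3 `CC(C)C[C@H](N)CN(C(=O)[C@@H]1C[C@H]1c1ccccc1)c1ccc(-c2ccncc2)cc1` gives 13000 nM, the highest of the two single numbers shown so far; its nearest neighbour, compound 2 `CC[C@H](C)[C@H](N)CN(C(=O)[C@@H]1C[C@H]1c1cccnc1)c1ccc(-c2ccccc2)cc1`, gives 1500 nM, a gap beyond the usual scatter. Compound 1 `CC[C@H](C)[C@H](N)CN(C(=O)[C@@H]1C[C@H]1c1ccccc1)c1ccc(-c2ccccc2)cc1` has two entries, (the several entries of compound 1 in this assay, 230 nM; 800 nM (2 entries)), so in this assay compound 1 gives 230 nM; 800 nM (2 entries). Going by the values given here, compound 2 and compound 3 each differ from compound 1 in more than one place, so no step between measured compounds that differ in a single place is available.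

Compound 4 `CC(C)C[C@H](N)CN(C(=O)[C@@H]1C[C@H]1c1ccccc1)c1ccc(-c2cccc(C#N)c2)cc1` is the next entry: 3-cyanophenyl in place of pyridin-4-yl on an aromatic carbon. The change from compound 3 keeps the amine side chain of compound 3 and alters only the distal ring, a ring of carbon only, as in compound 1. Among the compounds with values here, no measured pair shows this exact change. For compound 4 the expected step in this assay is a 5.2-fold lower number from compound 3 to compound 4 (0.72 log units; beyond the scatter), toward a lower number and beyond the scatter. Compound 4 is therefore estimated at 2500 nM, with a range of 500 nM to 12000 nM.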

Compound 4, half-maximal effective concentration: 4500 nM
Beside the measured number, compound 4's estimate is 1.8-fold (0.26 log units) below it; the range from low to high includes it.
By their numbers in this assay, from the lowest: compound 2; then compound 4; then compound 3.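

In this assay, going by these compounds alone, the exchange of pyridin-4-yl for 3-cyanophenyl gives a 2.9-fold lower number from compound 3 to compound 4 (0.46 log units; beyond the scatter), the first step that can be read at a single place. With this amine side chain, the distal ring therefore does not need its ring nitrogen for the response, and a ring of carbon only carrying a nitrile is tolerated on an aromatic carbon, para to a large group. Nothing in the data shown accounts for the size of this step.

From the compounds shown here alone, it remains open how much of the step belongs to the nitrile and how much to the ring of carbon only, and whether it carries over to the side chain of compound 1. Also open, going by these compounds, is how a carboxylic acid or a methoxy group would read on the same ring.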